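Anilide to free acid: working notes on compound 4

The compounds below may be only part of what the source reports. "The series", "measured", "known", "first", "only" and "open" are said of these compounds alone.

Compound 1 `COc1ccc(Cl)cc1S(=O)(=O)Nc1cncc(C(=O)Nc2ccccc2)c1` has no number in an assay on isolated protein for inhibition of alkaline phosphatase, tissue-nonspecific isozyme (Homo sapiens); a lower number here means a stronger inhibitor, a higher number a weaker inhibitor: for compound 1 the entry reads "not determined" (no result reported). The same holds for compound 3 `COc1ccc(C(N)=O)cc1S(=O)(=O)Nc1cccnc1`, for which this assay shows "not determined" (no result reported). Going by the values given here, the only value of the set comes from compound 2 `COc1ccc(OC(F)(F)F)cc1S(=O)(=O)Nc1cncc(C(N)=O)c1`, which in this assay gives 1560 nM. Compound 4 `COc1ccc(Cl)cc1S(=O)(=O)Nc1cncc(C(=O)O)c1` differs from compound 1 in one place: hydroxy in place of anilino on a carbonyl carbon. Among the compounds with values here, no measured pair shares this change, so the size of the step in this assay cannot be read from measured neighbours; a shift of moderate size in either direction, or none beyond the scatter, is possible. With compound 2 as the only anchor, compound 4 is expected to fall near 2000 nM, within a range of 300 nM to 15000 nM.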

Compound 4, half-maximal inhibitory concentration: > 20000 nM
Compound 4 ended at the assay's limit (the forecaster's own chance of this, stated with the estimate: 20%); middle value at least 10-fold (1.00 log units) away from the limit.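

No step can be read between compound 1 and compound 4. In this assay, compound 4 gives > 20000 nM, which is a limit of the assay. The compounds shown leave open how far replacing phenylcarbamoyl with carboxy shifts inhibition.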